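Trifluoromethyl for fluoro on a quinoline carboxylic acid

This account rests on a few compounds, and the source may have more. Where it says the series, first, only, none or still open, it means among the compounds named here.

The account concerns compound 1 `O=C(O)c1cnc2c(F)cccc2c1` and its relative compound 4 `O=C(O)c1cnc2c(C(F)(F)F)cccc2c1`. In a functional assay on the whole organism (strain Sprague-Dawley) for inhibition, with Rattus norvegicus as the target (on this read-out lower numbers stand for an effect already at smaller amounts and higher numbers for an effect only at larger amounts of compound), compound 1 gives > 25 mg/kg, which is a limit of the assay and not a number. Compound 2 `O=C(O)c1cnc2c(F)cc(F)cc2c1` gives 25 mg/kg in this assay. Compound 3 `Fc1cccc2cc(-c3nn[nH]n3)cnc12` gives > 10 mg/kg in this assay, again a limit rather than a number. The change from compound 1 to compound 2 is fluoro in place of hydrogen on an aromatic carbon, with a number no higher from compound 1 to compound 2 (the limit leaves the size open). The change to compound 3 is 2H-tetrazol-5-yl in place of carboxy on an aromatic carbon, with a step that the two limits leave unreadable from compound 1 to compound 3. Compound 4 carries a different change, (trifluoromethyl in place of fluoro on an aromatic carbon), and neither measured step tells how such a change moves the read-out. For the measured compounds named here, compound 1 itself stands only at a limit, so no measured step gives a readable size to carry over. Compound 4 is therefore expected to give about 30 mg/kg, within a range of 10 mg/kg to 100 mg/kg. The expected step that the limit leaves unreadable from compound 1 to compound 4 is estimated to stay within the scatter, and a limit is the most likely outcome.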

Compound 4, minimum effective dose: 50 mg/kg
For compound 4 the middle estimate is 1.7-fold (0.22 log units) below the measured one; measured number inside the range.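

No step between compound 1 and compound 4 can be read, because compound 1 stands only at a limit and not at a number: the limit of > 25 mg/kg in this assay, at which 1 of the 4 values shown sits.

The compounds shown leave open whether trifluoromethyl in place of fluoro moves the minimum effective dose at all, and in which direction.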